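The source may hold more compounds than are shown below. What is called first, only, known or untested is meant among the compounds shown, and "the series" means these compounds.

Measured so far in a functional assay on HepG2 cells (Homo sapiens) for inhibition, read by MTT assay, with a stated time of 48 h; a lower number here means a stronger inhibitor, a higher number a weaker inhibitor:
- compound 1 `Cc1nc(N(C)c2ccc([Se]C#N)c(C)c2)c2ccccc2n1`: 9 nM
- compound 2 `COc1ccc(N(C)c2nc(C)nc3ccccc23)cc1C(=O)OCCC[Se]C#N`: 340 nM

Of these two, compound 2 has the higher number at 340 nM, which makes it the weaker inhibitor. Compound 1 gives 9 nM, and the gap between them lies beyond the usual scatter of repeated measurements.

Compound 3 `COc1ccc(N(C)c2nc(C)nc3ccccc23)cc1[Se]C#N` differs from compound 2 in one place: a group of 3 heavy atoms (1 carbon, 1 nitrogen, 1 selenium; no ring) in place of a group of 9 heavy atoms (5 carbon, 1 nitrogen, 2 oxygen, 1 selenium; no ring), on an aromatic carbon. The smaller group sits on an aromatic carbon of the ring, ortho to a methoxy group and meta to a large group.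

Among the compounds with values here, no pair of measured compounds shows this exchange on its own, so any forecast is indirect. Within the data shown here, the one guide is compound 1 at 9 nM, which carries the same small group on an aromatic carbon, though it differs from compound 3 elsewhere too. A clear drop in this assay, beyond the scatter, is therefore expected. The expected change is a 14-fold lower number from compound 2 to compound 3 (1.13 log units; beyond the scatter). For compound 3 the estimate is 25 nM, with an expected range from 5 nM to 120 nM.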

Compound 3, half-maximal inhibitory concentration: 59 nM
For compound 3 the middle estimate is 2.4-fold (0.37 log units) below the measured one, within the range that was stated.
By their numbers in this assay, from the lowest: compound 1; then compound 3; then compound 2.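

In this assay, within the data shown here, this pair gives the first direct reading at this position: with the rest of the molecule unchanged, placing the group of 3 heavy atoms on the aromatic carbon ortho to a methoxy group, in place of the group of 9 heavy atoms, gives a 5.8-fold lower number from compound 2 to compound 3 (0.76 log units; beyond the scatter), a modest step. Both compounds carry selenium and a nitrile, so having those atoms somewhere in this group does not by itself fix the number; how they are attached to the aromatic ring also goes with a real difference in this pair. Nothing measured here explains why the number moves with this exchange.

From the compounds shown here alone, the carbonyl and the carbon chain of compound 2 leave together in this one exchange, so their separate shares in the step remain open. Also open, going by these compounds, is how a carboxylic acid or an amine on this same aromatic carbon would read, and whether a shorter chain ending in selenium and nitrile would fall between compound 2 and compound 3.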